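Swapping chloro for methyl on a fused pyrazolopyrimidine amine

This account rests on a few compounds, and the source may have more. Where it says the series, first, only, none or still open, it means among the compounds named here.

Three compounds have been measured in a functional assay on the whole organism (strain Wistar) for inhibition, with Rattus norvegicus as the target, read by paw edema, with stated times of 30 min and 4 h, at a dose of 50 mg/kg by the oral route; a lower number here means less inhibition, a higher number more inhibition at the dose given (going by the name of the read-out):

Compound 1, `Nc1cc(-c2ccc(Br)cc2)nc2cc(-c3ccc(Cl)cc3)nn12`: 76.2%
Compound 2, `Cc1ccc(-c2cc3nc(-c4ccc(Br)cc4)cc(N)n3n2)cc1`: 66.7%
Compound 3, `Nc1cc(-c2ccc(Cl)cc2)nc2cc(-c3ccc(Br)cc3)nn12`: 65.5%

Compound 1 and compound 3 are built from the same atoms joined differently; the difference between the two cores is not broken down here. Their values in this assay lie apart by more than the usual scatter, with compound 1 giving the higher number. Compound 2 and compound 3 give numbers within the scatter of each other, so nothing can be said about their order.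

One structural change appears twice among these compounds. From compound 1 to compound 2 the change is methyl in place of chloro on an aromatic carbon, and it produced a number 9.5 percentage points lower from compound 1 to compound 2 (within the scatter). The same change, at the same place, leads from compound 3 to compound 4, `Cc1ccc(-c2cc(N)n3nc(-c4ccc(Br)cc4)cc3n2)cc1`, namely (methyl in place of chloro on an aromatic carbon).

For the measured compounds named here, since the one measured instance of this change gave a step within the scatter, compound 4 is expected to sit close to compound 3 in this assay, with a step of about a number 7.5 percentage points lower from compound 3 to compound 4 (within the scatter), resting on the step from compound 1 to compound 2 and on the value of compound 3, 65.5%. For compound 4 the estimate in this assay is 58%, expected to fall between 45% and 70%.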

Compound 4, a percentage reported as inhibition, in the whole organism at one dose (the size of the read-out at that dose, not a potency): 64.3%
The estimate for compound 4 lay 6.3 percentage points below the measured number; low and high end bracket the measured number.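

In this assay, replacing 4-chlorophenyl with 4-methylphenyl on the second core gave a number 1.2 percentage points lower from compound 3 to compound 4 (within the scatter) and so adds a second instance of this change to the first. Set side by side, the two instances cannot be told apart: the same change on two cores in this assay, a number 9.5 percentage points lower (within the scatter) from compound 1 to compound 2 and a number 1.2 percentage points lower (within the scatter) from compound 3 to compound 4, 8.3 percentage points apart, within the scatter of two such steps. This shows that, across these two cores, the change from chloro to methyl gave no step larger than repeated measurements would be expected to produce; it does not show that the change does nothing or that its size is the same on both cores, as a small real effect could be hidden within the scatter, and two instances are too few to make a rule for the series.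

On these data alone, only chloro, methyl and bromo appear on the two aromatic rings carried by these cores, so it remains open how a different group, such as methoxy, a longer chain or a carboxylic acid, would behave in place of the chloro. Also open is what would happen if the amine on the core were replaced by another group, such as an amide, as all the compounds shown keep that amine.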